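The source may hold more compounds than are shown below. What is called first, only, known or untested is meant among the compounds shown, and "the series" means these compounds.

Measured compounds in an ADME assay on microsomes from liver (Mus musculus) for metabolic stability, read by LC-MS, with a stated time of 10 min; a higher number here means that more of the compound is left, a lower number that less of the compound is left:
Compound 1 `c1cnc2c(c1)CCC[C@@H]2N(CC1CCCCC1)C[C@H]1Cc2c(cccc2N2CCNCC2)CN1` gives 85.6%.
Compound 2 `CN(C[C@H]1Cc2c(cccc2N2CCN3CCC[C@@H]3C2)CN1)[C@H]1CCCc2cccnc21` gives 36.7%.
Compound 3 `CN1CCN(c2cccc3c2C[C@H](CN(C)[C@H]2CCCc4cccnc42)NC3)CC1` gives 17%.

Compound 1 holds the highest of the three numbers in this assay: compound 2 stands well below it, and compound 3 lower still. Going by the values given here, the only step between neighbours that differ in one place runs from compound 2 to compound 3, on an aromatic carbon, where the change of the ring group gave a number 19.7 percentage points lower from compound 2 to compound 3 (beyond the scatter). That step touches a different part of the molecule from the one that matters here.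

Compound 4 `CCN(C[C@H]1Cc2c(cccc2N2CCNCC2)CN1)[C@H]1CCCc2cccnc21` differs from compound 1 by methyl in place of cyclohexyl on a saturated chain carbon bound to an amine nitrogen. Among the compounds with values here, no measured pair shows this change alone; compounds 2 and 3 both carry a methyl on the amine nitrogen but also differ from compound 1 elsewhere, so their values only hint that a smaller group there goes with lower numbers. Compound 4 is therefore expected to fall below compound 1, with an estimated step of a number 30.6 percentage points lower from compound 1 to compound 4 (beyond the scatter). The estimate for compound 4 in this assay is 55%, within 25% to 85%.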

Compound 4, percent of the compound remaining: 53.8%
For compound 4 the middle estimate is 1.2 percentage points above the measured one; measured number inside the range.
By their numbers in this assay, from the lowest: compound 3; then compound 2; then compound 4; then compound 1.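

In this assay, the change from cyclohexyl to methyl on a saturated chain carbon bound to an amine nitrogen gave a number 31.8 percentage points lower from compound 1 to compound 4 (beyond the scatter). This pair shows the change alone, with the rest of the molecule held constant, so the cyclohexylmethyl compound can be set directly against the ethyl compound, which compounds 2 and 3 could not do because they also differ from compound 1 elsewhere. No measurement given here accounts for this step.

The compounds shown leave open where between ethyl and cyclohexylmethyl the number changes, as a propyl chain, a cyclopropylmethyl group or a benzyl group at this place could indicate. They also leave open whether the same change gives a step of similar size with the ring groups of compound 2 or compound 3.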